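Amino for chloro on a second benzyl-substituted core

The source may report more compounds than this note shows. Statements on the series, on what has been measured and on what is new or still open speak of the compounds shown alone.

Measured compounds:
compound 1, `ClCc1ccccc1Cn1cnc2c(Cl)nc(Cl)nc21`, 420 nM
compound 2, `ClCc1cccc(Cn2cnc3c(Cl)nc(Cl)nc32)c1`, 1580 nM
compound 3, `Nc1nc(Cl)c2ncn(Cc3ccccc3CCl)c2n1`, 15500 nM

Three compounds were tested in a functional assay on UO-31 cells (Homo sapiens) for cytotoxicity, read by sulforhodamine B assay, with a stated time of 48 h; on this read-out lower numbers stand for stronger inhibition of growth and higher numbers for weaker inhibition of growth. Compound 1 and compound 2 share the same atoms joined differently; the difference between the two cores is not broken down here. Compound 3 is obtained from compound 1 by one change, (amino in place of chloro on an aromatic carbon), and this change brought a 37-fold higher number from compound 1 to compound 3 (1.57 log units; beyond the scatter).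

Compound 4, `Nc1nc(Cl)c2ncn(Cc3cccc(CCl)c3)c2n1`, has not yet been tested. It is obtained from compound 2 by the same change, (amino in place of chloro on an aromatic carbon). Since the step from compound 1 to compound 3 was large and beyond the scatter, a step of similar size is expected for compound 4 in this assay, a 32-fold higher number from compound 2 to compound 4 (1.50 log units; beyond the scatter), resting only on that single earlier example. The value for compound 4 is therefore estimated at 50000 nM, with a range from 15000 nM to 150000 nM.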

Compound 4, concentration for 50% growth inhibition: 13500 nM
For compound 4 the middle estimate is 3.7-fold (0.57 log units) above the measured one, and the stated range ends above it.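

In this assay, amino in place of chloro on the core of compound 2 gave an 8.5-fold higher number from compound 2 to compound 4 (0.93 log units; beyond the scatter) and so weaker inhibition of growth, as it had on the core of compound 1. The direction of the change carried over from one core to the other, but its size did not: the same change on two cores in this assay, a 37-fold higher number (1.57 log units; beyond the scatter) from compound 1 to compound 3 and an 8.5-fold higher number (0.93 log units; beyond the scatter) from compound 2 to compound 4, 4.3-fold (0.64 log units) apart, beyond the scatter of two such steps

Among the compounds shown here, with only two cores, this does not show what sets the size of the step or how it would turn out on any further core. The compounds shown leave open whether a methoxy or dimethylamino group in the same place would act as amino does. They also leave open what a hydroxymethyl group in place of the chloromethyl group would do.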